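The source may hold more compounds than are shown below. What is called first, only, known or untested is meant among the compounds shown, and "the series" means these compounds.

Within the data shown here, compound 1 `O=C(NO)c1ccc(CN2C(=O)/C(=C3\Nc4ccccc4\C3=N/O)c3cc(F)ccc32)cc1` gives 30 nM in a functional assay on NCI-H23 cells (Homo sapiens) for cytotoxicity, read by colorimetric assay (on this read-out higher numbers stand for weaker inhibition and lower numbers for stronger inhibition), and holds the higher of the two numbers so far, while compound 2 `O=C(/C=C/c1ccc(CN2C(=O)/C(=C3\Nc4ccccc4\C3=N/O)c3cc(F)ccc32)cc1)NO` gives 8 nM on the same read-out. Compound 3 `O=C(NO)c1ccc(CN2C(=O)/C(=C3\Nc4ccccc4\C3=N/O)c3cc(Br)ccc32)cc1` keeps the structure of compound 1 except for one substituent. The change bromo in place of fluoro on an aromatic carbon is bromo in place of fluoro on an aromatic carbon of the six-membered ring of carbon only. Among the measured compounds shown here, only one measured step bears on this, a 3.8-fold lower number from compound 1 to compound 2 (0.57 log units; beyond the scatter) and it alters the hydroxycarbamoyl group, a different place in the molecule. For the measured compounds named here, its size shows how far a single change can move the number in this assay but no measured pair swaps fluoro for bromo, so it gives no direction here. The expected result is no change at the digits printed from compound 1 to compound 3 (within the scatter) with no shift beyond the scatter. For compound 3 the estimated value is 30 nM with an expected range from 12 nM to 75 nM in this measurement.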

Compound 3, half-maximal inhibitory concentration: 7 nM
Compound 3: the middle estimate sits 4.3-fold (0.63 log units) above what was measured; measured number below the stated range.
By their numbers in this assay, from the lowest: compounds 3 and 2 (each within the scatter of the next); then compound 1.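

Replacing fluoro with bromo on this aromatic carbon, with the rest of compound 1 unchanged, gives a 4.3-fold lower number from compound 1 to compound 3 (0.63 log units; beyond the scatter) in this assay. The earlier step altered the hydroxycarbamoyl group, so this result adds a second place in the molecule where a single change moves the number beyond the scatter: a swap of one halogen atom for another on the six-membered ring is enough. Nothing available explains why the bromo compound gives the lower number.

On these data alone, with only fluoro and bromo at this position, it remains open where a chloro, an iodo, a methoxy group or a plain hydrogen would fall. As far as these compounds go, it is also open whether bromo and the 2-(hydroxycarbamoyl)ethenyl group would lower the number further if carried together in one compound.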